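This account rests on a few compounds, and the source may have more. Where it says the series, first, only, none or still open, it means among the compounds named here.

Measured compounds in this set:

compound 1, `CCOC(=S)SCC(=O)c1ccc(NC(C)=O)cc1` — 90 nM
compound 2, `COCCSC(=S)SCC(=O)c1ccc(OC)cc1` — 2130 nM
compound 3, `CCNC(=O)SCC(=O)c1ccc(OC)cc1` — 132 nM

All three were run in an assay on HEK293 cells for inhibition of protein deacetylase HDAC6 (Homo sapiens); a higher number here means a weaker inhibitor, a lower number a stronger inhibitor. Compound 3 sits second highest of the three numbers. Its nearest neighbour is compound 1, whose number is lower by a margin that stays within the scatter, so no order between compound 3 and compound 1 can be read from these two values. The furthest is compound 2, whose number is higher by a margin well beyond the scatter, so compound 2 is clearly the weaker of that pair.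

The next compound, compound 4, `CCOC(=S)SCC(=O)c1ccc(OC)cc1`, has not yet been measured in this assay. It differs from compound 3 in one place: a group of 5 heavy atoms (3 carbon, 1 oxygen, 1 sulfur; no ring) in place of a group of 5 heavy atoms (3 carbon, 1 nitrogen, 1 oxygen; no ring), on a sulfur.

Going by the values given here, no step between two measured compounds matches this change, so the expected size rests on the structures alone. Compound 4 shares its entering group with compound 1, and compound 1 gives 90 nM, close to compound 3. This suggests the step is expected to be small, in either direction, and not beyond the scatter: expected step a 1.1-fold lower number from compound 3 to compound 4 (0.04 log units; within the scatter). On that basis compound 4 is estimated at 120 nM, with a range from 40 nM to 400 nM.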

Compound 4, half-maximal inhibitory concentration: 448 nM
For compound 4 the middle estimate is 3.7-fold (0.57 log units) below the measured one, and the stated range ends below it.
By their numbers in this assay, from the lowest: compounds 1 and 3 (each within the scatter of the next); then compound 4; then compound 2.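

In this assay the sulfur-bound position proves sensitive to its group: replacing ethylcarbamoyl with the group carried by compound 4 gives a 3.4-fold higher number from compound 3 to compound 4 (0.53 log units; beyond the scatter), so the two are not interchangeable on this core. The other two places respond as well, with ethoxy in place of (2-methoxyethyl)sulfanyl on a thiocarbonyl carbon giving a 4.8-fold lower number from compound 2 to compound 4 (0.68 log units; beyond the scatter), and methoxy in place of acetamido on an aromatic carbon giving a 5.0-fold higher number from compound 1 to compound 4 (0.70 log units; beyond the scatter). Compound 1 and compound 3 differ in two places, and these one-place steps show that their close values did not mean that either place is without effect.

Still open, as far as these compounds go, is whether the step at the sulfur tracks the amide hydrogen, which a dimethylcarbamoyl group would test, and whether acetamido on the aromatic carbon would also lower the number when ethylcarbamoyl stands on the sulfur, or whether a free amine there would do the same. Nothing available for this series accounts for the size or direction of these steps.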